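The compounds below may be only part of what the source reports. "The series", "measured", "known", "first", "only" and "open" are said of these compounds alone.

Working notes on the series.

Two compounds have numbers in an assay on cells for antagonist activity at transient receptor potential cation channel subfamily V member 1 (Homo sapiens), read by FLIPR and calcium flux, with a stated time of 15 min; a higher number here means a weaker inhibitor, a lower number a stronger inhibitor. Compound 1, `CC1CCN(c2nc(C(F)(F)F)ccc2CNC(=O)C(C)c2ccc(NS(C)(=O)=O)c(Cl)c2)CC1`, gives 2.3 nM in this assay. Compound 2, `CC1CCN(c2nc(C(F)(F)F)ccc2CNC(=O)C(C)c2ccc(NS(N)(=O)=O)c(F)c2)CC1`, gives 2.7 nM in this assay. For the measured compounds named here, of the two numbers, the one for compound 2 is the higher, but the two values lie within the scatter of each other, so nothing can be said about an order between compound 1 and compound 2 on this basis.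

The next compound in the series is compound 3, `CC(=O)N(c1ccc(C(C)C(=O)NCc2ccc(C(F)(F)F)nc2N2CCC(C)CC2)cc1F)S(C)(=O)=O`. It differs from compound 2 in one place: acetyl(methylsulfonyl)amino in place of sulfamoylamino on an aromatic carbon. The sulfamoylamino group that leaves carries two hydrogen-bond donors; the acetyl(methylsulfonyl)amino group that enters carries none and is larger by three heavy atoms. Going by the values given here, no measured pair shows a step of this kind, so the size of the effect can only be guessed from the structural change itself.

The expectation for compound 3 in this assay is a weakening, the step from compound 2 to compound 3 estimated as a 4.4-fold higher number from compound 2 to compound 3 (0.65 log units; beyond the scatter), beyond the scatter but moderate. Compound 3 is therefore estimated at 12 nM in this assay, with a range from 3 nM to 60 nM.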

Compound 3, inhibition constant: 11.9 nM
Compound 3: middle estimate off by 1.0-fold (0.00 log units), on the high side; the measured number falls inside the stated range.
By their numbers in this assay, from the lowest: compounds 1 and 2 (each within the scatter of the next); then compound 3.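

For the compounds shown here, at the aromatic carbon ortho to a fluoro group and para to a large group, acetyl(methylsulfonyl)amino in place of sulfamoylamino gives a 4.4-fold higher number from compound 2 to compound 3 (0.64 log units; beyond the scatter) in this assay, the first step that can be read at this place. The number at this place therefore responds to the group it carries, yet the entering group has no hydrogen-bond donors and compound 3 still gives 11.9 nM, so in this pair the sulfamoylamino group and its donors are not needed for activity in the nanomolar range. No measurement shown here ties the step to the loss of those donors, to the larger size of the entering group or to any other single feature of the change.

From the compounds shown here alone, it remains open which part of the acetyl(methylsulfonyl)amino group carries the step, as the acetyl and the methylsulfonyl parts are not separated in this pair. Also open, going by these compounds, is how a methylsulfonylamino group, a plain amine or a carboxylic acid at this place would compare with compound 2 and compound 3 when the rest of the structure is held the same.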